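Carboxy in Place of Fluoro: Expected Cytotoxicity

A few compounds are considered here, and "the series" means these few. Any claim that something is new, unique, unknown or untested is made for them only; others in the source may bear on it.

Compound 1 `CCOC(=O)c1cn(-c2nccs2)nc1CC(C)C` carries a 1,3-thiazol-2-yl group on a ring nitrogen of the shared core. In a toxicity assay on HepG2 2.2.15 cells (Homo sapiens) for cytotoxicity, read by CCK-8 assay, with a stated time of 8 days (on this read-out lower numbers stand for higher toxicity in this test and higher numbers for lower toxicity in this test), compound 1 gives only a limit, > 100000 nM, and not a number. Compound 2 `CCOC(=O)c1cn(-c2ccc(F)cc2)nc1CC(C)C` is its 4-fluorophenyl counterpart. In this assay compound 2 likewise reaches only the limit > 100000 nM. The step that the two limits leave unreadable from compound 1 to compound 2 is thus unreadable, both values sitting at the limit of > 100000 nM in this assay, at which 2 of the 2 values shown sit. Compound 3 `CCOC(=O)c1cn(-c2ccc(C(=O)O)cc2)nc1CC(C)C` differs from compound 2 by carboxy in place of fluoro on an aromatic carbon. Within the data shown here, the single measured step touches another position and yields no size, so it gives no direction for this change; both measured compounds simply show no cytotoxicity within the tested range. Compound 3 is therefore expected to stay at the limit as well, an expected step that the limit leaves unreadable from compound 2 to compound 3 in this assay. The estimate for compound 3 in this assay is 150000 nM, within a range from 50000 nM to 500000 nM.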

Compound 3, half-maximal cytotoxic concentration: > 100000 nM
Compound 3 was reported as a limit; the forecaster's own chance of this, stated with the estimate: 85%; the middle value lies beyond the limit too.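

Among these compounds, compound 2 and compound 3 are both reported only as limits in this assay, so no step between them can be read: the limit of > 100000 nM in this assay, at which 3 of the 3 values shown sit. The compounds shown leave open whether any change on the shared core would produce a measurable cytotoxic concentration in this assay.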